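The compounds below may be only part of what the source reports. "The series", "measured", "known", "first", "only" and "open" are said of these compounds alone.

Compound 1 `NC(=O)c1c(NC(=O)c2ccccc2Br)sc2c1CCN(C(=S)Nc1ccccc1C(F)(F)F)C2` and compound 2 `Cc1ccccc1NC(=S)N1CCc2c(sc(NC(=O)c3ccccc3Br)c2C(N)=O)C1` share a core and differ in one place: methyl in place of trifluoromethyl on an aromatic carbon. In a functional assay on HeLa cells (Homo sapiens) for antiproliferative activity, with a stated time of 24 h (a lower number here means a stronger inhibitor, a higher number a weaker inhibitor), compound 1 gives 39600 nM. Compound 2 reaches only a limit of this assay, > 50000 nM, so no number is known for it. The step therefore reads as an at least 1.2-fold higher number from compound 1 to compound 2 (0.10 log units; that floor lies within the scatter), and it rests on (the limit of > 50000 nM in this assay, at which 1 of the 3 values shown sits). Compound 3 `NC(=O)c1c(NC(=O)c2ccc(C(F)(F)F)cc2)sc2c1CCN(C(=S)Nc1cc(C(F)(F)F)cc(C(F)(F)F)c1)C2` carries a different core, and how the two cores differ is not broken down here; in this assay compound 3 gives 49000 nM, which sits within the scatter of compound 1. Compound 4 `Cc1ccc(C(=O)Nc2sc3c(c2C(N)=O)CCN(C(=S)Nc2cc(C(F)(F)F)cc(C(F)(F)F)c2)C3)cc1` is derived from compound 3 by the same kind of change, though not the same one: methyl in place of trifluoromethyl on an aromatic carbon. Around the place, compound 2 has the methyl ortho to a large group, whereas compound 4 has it para to a large group. Given the step from compound 1 to compound 2, compound 4 is expected to move by about a 1.3-fold higher number from compound 3 to compound 4 (0.12 log units; within the scatter), most likely ending at a limit. The estimate for compound 4 in this assay is 65000 nM, between 30000 nM and 150000 nM.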

Compound 4, half-maximal inhibitory concentration: 17100 nM
Compound 4: middle estimate off by 3.8-fold (0.58 log units), on the high side, outside the stated range (below it).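

In this assay, methyl in place of trifluoromethyl gives a 2.9-fold lower number from compound 3 to compound 4 (0.46 log units; beyond the scatter), so the change does not carry over from one core to the other as a single shift: the same change on two cores in this assay, an at least 1.2-fold higher number (0.10 log units; that floor lies within the scatter) from compound 1 to compound 2 and a 2.9-fold lower number (0.46 log units; beyond the scatter) from compound 3 to compound 4, at least 3.6-fold (0.55 log units) apart, beyond the scatter of two such steps. The comparison has a soft edge, since the earlier step rests on a limit and not on a number: the limit of > 50000 nM in this assay, at which 1 of the 4 values shown sits. The data show that the result of this change depends on its setting, but they do not show what sets it, since the two pairs differ both in the core and in where the change sits, and two pairs make no rule for the series.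

The compounds shown leave open whether the lower number of compound 4 belongs to the 4-methylphenyl group alone or would also appear with an ethyl, a methoxy or an amine at that place. They also leave open whether the same change would give a readable step on the core of compound 1, where one partner stands at a limit.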